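Swapping a fluorophenyl for a dihydropyranyl on the shared core

A few compounds are considered here, and "the series" means these few. Any claim that something is new, unique, unknown or untested is made for them only; others in the source may bear on it.

Measured so far:
compound 1 `O=C(Nc1cccc(F)c1)c1cc(=O)[nH]c2cc(F)ccc12`: > 20000 nM in a functional assay on KYSE-410 cells (Homo sapiens) for antiproliferative activity, read by MTT assay, with a stated time of 72 h; on this read-out higher numbers stand for weaker inhibition and lower numbers for stronger inhibition
compound 2 `O=C(Nc1cccc(F)c1)c1cc(=O)[nH]c2cc(-c3ccccc3F)ccc12`: > 20000 nM

The two measured values are both limits of the assay rather than numbers. In this assay compound 1 gives > 20000 nM, a limit. In this assay compound 2 also gives only a limit, > 20000 nM. For the measured compounds named here, the only measured step, a step that the two limits leave unreadable from compound 1 to compound 2, is therefore unreadable in size. Compound 2 thus stands at the same limit as compound 1, and nothing about its position below that limit is known; (the limit of > 20000 nM in this assay, at which 2 of the 2 values shown sit).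

Compound 3 `O=C(Nc1cccc(F)c1)c1cc(=O)[nH]c2cc(C3=CCOCC3)ccc12` differs from compound 2 by a group of 6 heavy atoms (5 carbon, 1 oxygen; one six-membered non-aromatic ring with 1 hetero atom) in place of a group of 7 heavy atoms (6 carbon, 1 fluorine; one six-membered aromatic ring of carbon only), on an aromatic carbon. Going by the values given here, no measured step bears on this change, so there is no basis for expecting a step of a readable size in either direction. The expected outcome is that compound 3 again sits at the limit, with a step that the limit leaves unreadable from compound 2 to compound 3 as the estimated step and an estimate of 30000 nM, between 12000 nM and 80000 nM.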

Compound 3, half-maximal inhibitory concentration: 12100 nM
Compound 3: middle estimate off by 2.5-fold (0.39 log units), on the high side; the range from low to high includes it.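

In this assay, compound 3 is the only one of the three shown that gives a number rather than a limit, 12100 nM, so this aromatic carbon of the shared core can carry a group that brings the read-out into measurable range. The six-membered non-aromatic ring with 1 hetero atom gives an at least 1.6-fold lower number from compound 2 to compound 3 (0.21 log units; that floor lies within the scatter) when it replaces 2-fluorophenyl, and an at least 1.6-fold lower number from compound 1 to compound 3 (0.21 log units; that floor lies within the scatter) when it replaces fluoro, so neither step is shown to exceed the usual scatter, and their true sizes remain unknown. The step between compound 1 and compound 2 cannot be read, as both give only a limit: the limit of > 20000 nM in this assay, at which 2 of the 3 values shown sit.

From the compounds shown here alone, whether the ring oxygen or the double bond goes with the measured number stays open. Going by these compounds, how a piperidine or morpholine ring at this carbon would read in this assay also stays open.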